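A Sulfonamide Replaces the Pyridyl Ether on the Triazole

A few compounds are considered here, and "the series" means these few. Any claim that something is new, unique, unknown or untested is made for them only; others in the source may bear on it.

Three hydroxamic acids share one core and differ in the group carried on the side chain. Compound 1 `CC(C)[C@H](C(=O)NO)N(CCN=[N+]=[N-])S(=O)(=O)c1ccc(OCCF)cc1` gives 4 nM in an assay on isolated protein for inhibition of matrix metalloproteinase-9 (Homo sapiens), read by fluorescence, with a stated time of 30 min; on this read-out lower numbers stand for stronger inhibition and higher numbers for weaker inhibition. Compound 2 `COc1ccc(S(=O)(=O)N(CCn2cc(CCCF)nn2)[C@@H](C(=O)NO)C(C)C)cc1` gives 0.07 nM in this assay, and compound 3 `COc1ccc(S(=O)(=O)N(CCn2cc(CCCCOc3cccnc3F)nn2)[C@@H](C(=O)NO)C(C)C)cc1` gives 0.3 nM. Going by the values given here, compound 3 thus holds the second highest of the three numbers: its nearest neighbour is compound 2, separated from it by the step of a 4.3-fold higher number from compound 2 to compound 3 (0.63 log units; beyond the scatter), while compound 1 lies furthest from it with a clearly higher number and no single-point step connecting the two.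

Compound 4 `COc1ccc(S(=O)(=O)N(CCn2cc(CNS(=O)(=O)c3ccc(F)cc3)nn2)[C@@H](C(=O)NO)C(C)C)cc1` is not yet measured. It differs from compound 3 in one place: a group of 11 heavy atoms (6 carbon, 1 nitrogen, 2 oxygen, 1 fluorine, 1 sulfur; one six-membered aromatic ring of carbon only) in place of a group of 11 heavy atoms (8 carbon, 1 nitrogen, 1 oxygen, 1 fluorine; one six-membered aromatic ring with 1 hetero atom), on a saturated chain carbon bound to an aromatic carbon. Among the compounds with values here, no measured step exchanges one such group for another on this chain carbon. Within the data shown here, the only step that touches the same chain is the one already quoted, in which a larger group replaced a single fluorine and the number rose modestly. Compound 4 keeps a group of like size to that of compound 3, so the step of no change at the digits printed from compound 3 to compound 4 (within the scatter) is expected to stay within the scatter, in no clear direction. Compound 4 is therefore expected to give about 0.3 nM in this assay, within a range of 0.08 nM to 1.2 nM.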

Compound 4, half-maximal inhibitory concentration: 0.6 nM
The estimate for compound 4 lay 2.0-fold (0.30 log units) below the measured number; measured number inside the range.
By their numbers in this assay, from the lowest: compound 2; then compounds 3 and 4 (each within the scatter of the next); then compound 1.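

In this assay, the step of a 2.0-fold higher number from compound 3 to compound 4 (0.30 log units; within the scatter) shows that, on a saturated chain carbon bound to an aromatic carbon, one group of 11 heavy atoms can be exchanged for another without leaving the scatter, even though the entering ((4-fluorophenyl)sulfonyl)amino brings a six-membered aromatic ring of carbon only and 1 hydrogen-bond donor. The step of an 8.6-fold higher number from compound 2 to compound 4 (0.93 log units; beyond the scatter), in which ((4-fluorophenyl)sulfonyl)amino stands in place of 2-fluoroethyl, lies beyond the scatter, so among compounds 2, 3 and 4 both groups of 11 heavy atoms give a higher number than the smaller group of compound 2, and none of the three goes against this. Nothing measured on these compounds speaks to the reason for either step.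

The compounds shown leave open whether the fluorine on the phenyl ring of compound 4 plays any part, as a plain phenylsulfonylamino group would show. They also leave open how a small methylsulfonylamino group, an amine or a carboxylic acid would read on this chain carbon.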